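Fluoro on the sulfonyl aryl: expected step in compound 4

A few compounds are considered here, and "the series" means these few. Any claim that something is new, unique, unknown or untested is made for them only; others in the source may bear on it.

Compound 1 `CNCc1cc(-c2ccccc2)n(S(=O)(=O)c2ccc(C)cc2)c1` carries an unsubstituted phenyl on the shared core. In a functional assay on the whole organism (strain Jcl:SD) for inhibition, with Rattus norvegicus as the target, with stated times of 3 min and 3 h, at a dose of 1 mg/kg by the intravenous route (on this read-out higher numbers stand for more inhibition at the one dose given (going by the name of the read-out) and lower numbers for less inhibition), compound 1 gives 66%. Compound 3 `CNCc1cc(-c2ccccc2F)n(S(=O)(=O)c2ccc(C)cc2)c1` differs from compound 1 in one place, (fluoro in place of hydrogen on an aromatic carbon), and the step was a number 25 percentage points higher from compound 1 to compound 3 (beyond the scatter), so that in this assay compound 3 gives 91%. Compound 2 `CNCc1cc(-c2cccnc2F)n(S(=O)(=O)c2ccccc2)c1` is built on a different core; the difference between the two cores of compound 1 and compound 2 is not broken down here. In this assay compound 2 gives 99%, which is within the scatter of compound 3 and beyond the scatter of compound 1.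

Compound 4 `CNCc1cc(-c2cccnc2F)n(S(=O)(=O)c2cccc(F)c2)c1` has not yet been measured. It differs from compound 2 in one place, (fluoro in place of hydrogen on an aromatic carbon). The earlier change put fluoro ortho to a large group, whereas here fluoro enters meta to a large group, so this is the same kind of change, not the same change. The earlier step read a number 25 percentage points higher from compound 1 to compound 3 (beyond the scatter). The expectation for compound 4 rests on compound 2, which already gives 99%, leaving little room on this read-out. The step to compound 4 is therefore expected to be small, a number 3 percentage points lower from compound 2 to compound 4 (within the scatter). Compound 4 is estimated to give 96% in this assay. The range for compound 4 is expected to run from 85% to 100%.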

Compound 4, a percentage reported as inhibition, in the whole organism at one dose (the size of the read-out at that dose, not a potency) in the Rattus norvegicus assay: 99%
Estimate against measurement, compound 4: 3 percentage points below, within the range that was stated.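

In the Rattus norvegicus assay fluoro in place of hydrogen gave no change at the digits printed from compound 2 to compound 4 (within the scatter), which does not repeat the earlier step on the core of compound 1: the same change on two cores in the Rattus norvegicus assay, a number 25 percentage points higher (beyond the scatter) from compound 1 to compound 3 and no change at the digits printed (within the scatter) from compound 2 to compound 4, 25 percentage points apart, beyond the scatter of two such steps. For the compounds shown here, in the Rattus norvegicus assay compound 2 already gives 99%, leaving little room on this read-out, so the flat step shows neither that the change does nothing on this core nor that the core sets the size of the step; the fluoro also sits in a different place in the two pairs, and each core offers only one pair. The change does register in a physicochemical assay for lipophilicity, read by HPLC, at pH 7.4 (on this read-out lower numbers stand for lower lipophilicity and higher numbers for higher lipophilicity), where compound 2 gives -0.09 and compound 4 gives 0.23, which is a number 0.32 log units higher from compound 2 to compound 4 (beyond the scatter), though no such reading is shown for the core of compound 1.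

The compounds shown leave open how the 3-fluorophenyl would read on a core whose starting value lies lower on the scale, where a step could show in full. Also open, on these data alone, is whether chloro or methoxy at the same place, or an ethyl chain in place of the methyl on the amine, would separate from compound 4 in either read-out.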